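This account rests on a few compounds, and the source may have more. Where it says the series, first, only, none or still open, it means among the compounds named here.

Compound 3 `Cc1cccc(NC(=O)c2ccc(-c3ccccc3)cc2)n1` is the starting point of this step. In an in vitro assay on HEK-293T cells for displacement of a labelled ligand from metabotropic glutamate receptor 5 (Homo sapiens), read by scintillation counting (on this read-out higher numbers stand for weaker inhibition and lower numbers for stronger inhibition), compound 3 gives 7000 nM. Among the numbers shown it sits alongside compound 2 `Cc1cccc(NC(=O)c2ccc(Oc3ccccc3)cc2)n1`, which gives 7290 nM in this assay. That pair is separated by a 1.0-fold lower number from compound 2 to compound 3 (0.02 log units; within the scatter). Compound 1 `Cc1cccc(NC(=O)c2ccc(Br)cc2)n1` is reported in this assay only as a limit, > 10000 nM. From that limit the two steps are an at least 1.3-fold lower number from compound 1 to compound 2 (0.13 log units; that floor lies within the scatter) and an at least 1.4-fold lower number from compound 1 to compound 3 (0.15 log units; that floor lies within the scatter); both floors lie within the scatter, so neither shows a real change. Compound 4 `Cc1cccc(NC(=O)c2ccc(-c3cccc(Cl)c3)cc2)n1` differs from compound 3 by chloro in place of hydrogen on an aromatic carbon. Within the data shown here, none of the measured steps puts a chloro group in place of a hydrogen; the steps seen exchange a whole group on an aromatic carbon, and even those exchanges stay within the scatter or rest on floors that do. Nothing here points to a step beyond the scatter in either direction for this change. Compound 4 is therefore expected to give about 6000 nM, with the estimate ranging from 2500 nM to 14000 nM. The implied step is expected to be a 1.2-fold lower number from compound 3 to compound 4 (0.07 log units; within the scatter), which stays within the scatter.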

Compound 4, inhibition constant: 3330 nM
Compound 4: middle estimate off by 1.8-fold (0.26 log units), on the high side, and the stated range covers the measured number.
By their numbers in this assay, from the lowest: compound 4; then compounds 3 and 2 (each within the scatter of the next). At a limit, above all of these: compound 1.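

In this assay, adding a single chlorine to the outer phenyl, which turns it into 3-chlorophenyl, gives the first step among these compounds that lies beyond the scatter, with a 2.1-fold lower number from compound 3 to compound 4 (0.32 log units; beyond the scatter). The exchange of phenoxy and phenyl had shown no difference beyond the scatter, whereas 3-chlorophenyl in place of phenoxy does, with a 2.2-fold lower number from compound 2 to compound 4 (0.34 log units; beyond the scatter), so this small addition separates compounds that whole-group exchanges at the same end of the molecule had not. Among these compounds, the bromo compound is known only as a limit, which makes an at least 3.0-fold lower number from compound 1 to compound 4 (0.47 log units; beyond the scatter) a floor rather than a measured size, though it is the first floor from that limit to clear the scatter: the limit of > 10000 nM in this assay, at which 1 of the 4 values shown sits.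

The compounds shown leave open whether this step belongs to chloro itself or would also come with fluoro, methyl or methoxy at the same place, and whether chloro elsewhere on that ring would give it too. They also leave open what an amine or a carboxylic acid on this ring would do, and whether a change to the shared core would add to the step.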